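This account rests on a few compounds, and the source may have more. Where it says the series, first, only, none or still open, it means among the compounds named here.

Within the data shown here, in a functional assay on COR-L23 cells (Homo sapiens) for antiproliferative activity, read by CellTiter-Glo, with a stated time of 4 days (a lower number here means a stronger inhibitor, a higher number a weaker inhibitor), compound 3 `COCC(=O)N[C@@H](C)c1ccc(NC(=O)[C@H]2C[C@@H]2c2cccnc2)cc1` gives 111 nM, the lowest number so far. Compound 2 `CCC(=O)NC(C)(C)c1ccc(NC(=O)[C@H]2C[C@@H]2c2cccnc2)cc1` gives 2310 nM. For compound 1 `CCC(=O)NCc1ccc(NC(=O)[C@H]2C[C@@H]2c2cccnc2)cc1`, the assay reports only a limit, > 2500 nM.

The measured steps all change the group on the aromatic carbon. The step of an at least 1.0-fold lower number from compound 1 to compound 2 (0.03 log units; that floor lies within the scatter) shows no change beyond the scatter, whereas an at least 22-fold lower number from compound 1 to compound 3 (1.35 log units; beyond the scatter) and a 21-fold lower number from compound 2 to compound 3 (1.32 log units; beyond the scatter) are both large.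

Compound 4 `C[C@H](NC(=O)c1ccc(C#N)cc1)c1ccc(NC(=O)[C@H]2C[C@@H]2c2cccnc2)cc1` differs from compound 3 in one place: 4-cyanophenyl in place of methoxymethyl on a carbonyl carbon, with 4-cyanophenyl in place of methoxymethyl on a carbonyl carbon. Among the measured compounds shown here, no measured compound carries a ring there, so no step tests this change directly. The large step of a 21-fold lower number from compound 2 to compound 3 (1.32 log units; beyond the scatter) does show that this assay can respond strongly to a change within this group, so a sizeable shift in either direction remains possible. The best guess is a modest move towards a lower number, and the expected step is a 2.5-fold lower number from compound 3 to compound 4 (0.39 log units; beyond the scatter). For compound 4, the estimated value is 45 nM, with an expected range of 6 nM to 300 nM.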

Compound 4, half-maximal inhibitory concentration: 19 nM
Compound 4: the middle estimate sits 2.4-fold (0.37 log units) above what was measured; the range from low to high includes it.
By their numbers in this assay, from the lowest: compound 4; then compound 3; then compound 2. At a limit, above all of these: compound 1.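

In this assay the swap of methoxymethyl for 4-cyanophenyl on a carbonyl carbon gives a 5.8-fold lower number from compound 3 to compound 4 (0.77 log units; beyond the scatter) and thus shows that this position accepts a six-membered aromatic ring. The earlier compounds shown here carried only open chains here, whereas this group of 8 heavy atoms, replacing one of 3, goes with a lower number rather than a loss. Nothing measured here says why the number falls.

Among these compounds, with only one ring at this position, the effect of the ring cannot be separated from that of its nitrile, and a plain phenyl group or a phenyl ring bearing a carboxylic acid in place of the nitrile would help to tell them apart. As far as these compounds go, whether a saturated ring such as cyclohexyl or a chain ending in an amine would fit equally well also remains open.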